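The compounds below may be only part of what the source reports. "The series", "measured", "known", "first", "only" and "open" are said of these compounds alone.

Measured so far:
compound 1, `CCCCCCCCCCCO[C@@H]1[C@@H](N)[C@@H](O[C@H]2[C@H](O)[C@@H](OCCCCCCC)[C@H](N)C[C@@H]2N)O[C@H](CN)[C@H]1O`: 88.4%
compound 2, `NC[C@H]1O[C@H](O[C@H]2[C@H](O)[C@@H](OCc3ccc4ccccc4c3)[C@H](N)C[C@@H]2N)[C@H](N)[C@@H](OCc2ccc3ccccc3c2)[C@@H]1O`: 86%

In an ADME assay on J774 cells (Mus musculus) for cytotoxicity, read by MTT assay, with a stated time of 24 h, tested at 10 uM (a lower number here means a stronger effect, a higher number a weaker effect of the compound at the concentration tested), compound 1 stands highest of the two numbers, and compound 2 sits a little lower, within the scatter, so the pair shows no separation. Within the data shown here, no step between measured compounds differing in one place is available. Compound 3, `CCCCCCCO[C@@H]1[C@@H](O)[C@H](O[C@H]2O[C@H](CN)[C@@H](O)[C@H](O)[C@H]2N)[C@@H](N)C[C@H]1N`, is not yet measured; it differs from compound 1 by hydrogen in place of undecyl on an oxygen on a saturated carbon. Among the measured compounds shown here, with no measured step to draw on, the expectation rests on compound 1 and its 88.4%, already a weak effect. A small upward step of a number 5.6 percentage points higher from compound 1 to compound 3 (within the scatter) is expected, possibly no more than the scatter. Compound 3 is estimated at 94%, within a range from 82% to 104%.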

Compound 3, a percentage reported as activity, at one concentration (the size of the read-out at that concentration, not a potency): 84.3%
Beside the measured number, compound 3's estimate is 9.7 percentage points above it; the measured number falls inside the stated range.
By their numbers in this assay, from the lowest: compounds 3, 2 and 1 (each within the scatter of the next).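

In this assay, hydrogen in place of undecyl on an oxygen on a saturated carbon gives a number 4.1 percentage points lower from compound 1 to compound 3 (within the scatter). At this position, undecyloxy and hydroxy therefore cannot be told apart in this read-out at the concentration tested, so the undecyl chain is not shown to matter here. Nothing available explains this result. On these data alone, it remains open whether a shorter chain such as butyl, or a benzyl group, on this oxygen would separate from compound 1 and compound 3. Whether compound 1 and compound 3 also stay together at other concentrations is open too.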